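The compounds below may be only part of what the source reports. "The series", "measured", "known", "first", "only" and "open" are said of these compounds alone.

Compound 1 `COc1cc(C2=NN(C(C)=O)C(c3cccc(OC)c3OC)O2)cc(OC)c1OC` and compound 2 `COc1cc(C(=O)N/N=C/c2cccc(C(F)(F)F)c2)cc(OC)c1OC` were both tested in a functional assay on BGC-823 cells (Homo sapiens) for antiproliferative activity, read by MTT assay, tested at 5 uM; on this read-out higher numbers stand for a stronger effect at the one concentration tested and lower numbers for a weaker effect. In this assay compound 1 gives 17.5%, the lower of the two numbers, while compound 2 gives 33.8%, a result beyond the usual scatter between repeats. Compound 3 `COc1cc(C2=NN(C(C)=O)C(c3ccc(Cl)c([N+](=O)[O-])c3)O2)cc(OC)c1OC` has not yet been tested. It differs from compound 1 in one place (4-chloro-3-nitrophenyl in place of 2,3-dimethoxyphenyl on a saturated ring carbon). Among the measured compounds shown here, no measured pair shows a step of this kind, so the expected change from compound 1 to compound 3 is estimated as a number 4.5 percentage points higher from compound 1 to compound 3 (within the scatter), a shift not beyond the scatter. Compound 3 is therefore expected to give about 22%, within a range from 8% to 40%.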

Compound 3, a percentage reported as inhibition, at one concentration (the size of the read-out at that concentration, not a potency): 0%
Compound 3: the middle estimate sits 22 percentage points above what was measured, outside the stated range (below it).
By their numbers in this assay, from the lowest: compound 3; then compound 1; then compound 2.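

In this assay, putting 4-chloro-3-nitrophenyl in place of 2,3-dimethoxyphenyl on the saturated ring carbon gives a number 17.5 percentage points lower from compound 1 to compound 3 (beyond the scatter). This position is therefore sensitive to which substituents the phenyl ring carries, even though both groups count the same heavy atoms and hydrogen-bond acceptors. No measurement available here explains the drop. Still open, going by these compounds, is whether the chlorine or the nitro group alone accounts for the change, since both enter together. Also open, on these data alone, is how an amine or a carboxylic acid on this phenyl ring would fare.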